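This account rests on a few compounds, and the source may have more. Where it says the series, first, only, none or still open, it means among the compounds named here.

Working notes on the series in an assay on cells for displacement of a labelled ligand from Orexin receptor type 2 (Homo sapiens), read by scintillation counting, with stated times of 10 min and 90 min, tested at 10 uM; on this read-out higher numbers stand for more inhibition at the one concentration tested (going by the name of the read-out) and lower numbers for less inhibition. Of the compounds shown here, three have numbers so far. Compound 1 `COC(=O)c1cccc2c(C(=O)c3ccccc3)cc(C(=O)c3ccc(C(F)(F)F)cc3)c-2c1` gives 27%. Compound 2 `O=C(Oc1ccc2ccc(Cl)ccc1-2)c1ccccc1` gives 34.3%. Compound 3 `O=C(Oc1ccc2ccc(Cl)ccc1-2)c1cccs1` gives 33.2%. Compound 3 sits among the three numbers with a gap to compound 2 and a gap to compound 1 that are both within the scatter, so nothing separates compound 3 from the other two on this assay. Among the measured compounds shown here, the only measured step between compounds differing in one place is a number 1.1 percentage points lower from compound 2 to compound 3 (within the scatter), which is within the scatter.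

The next compound, compound 4 `O=C(Oc1ccc2ccc(Cl)ccc1-2)c1cccnc1`, is not yet measured in this assay. It differs from compound 3 by pyridin-3-yl in place of thiophen-2-yl on a carbonyl carbon. For the measured compounds named here, the step from compound 2 to compound 3 is the only one that bears on this change, since it also exchanged the group on the carbonyl carbon, and it was within the scatter; no measured pair contains pyridin-3-yl, so the new group itself has no precedent here. On that basis a step no larger than the scatter is expected, in either direction: a number 3.2 percentage points lower from compound 3 to compound 4 (within the scatter) is the estimated step. Compound 4 is therefore expected to give about 30%, within a range from 15% to 45%.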

Compound 4, a percentage reported as inhibition, at one concentration (the size of the read-out at that concentration, not a potency): 32.3%
Beside the measured number, compound 4's estimate is 2.3 percentage points below it; measured number inside the range.
By their numbers in this assay, from the lowest: compounds 1, 4, 3 and 2 (each within the scatter of the next).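

In this assay, the carbonyl carbon whose other neighbour is the ester oxygen now carries a six-membered aromatic ring containing nitrogen, and pyridin-3-yl in place of thiophen-2-yl gives a number 0.9 percentage points lower from compound 3 to compound 4 (within the scatter), while pyridin-3-yl in place of phenyl gives a number 2 percentage points lower from compound 2 to compound 4 (within the scatter). Within compounds 2, 3 and 4, the number therefore stays level across a change in aromatic ring size and in hetero atom at this position, without any separation on this read-out, and both new steps add to the earlier exchange of phenyl for thiophen-2-yl in showing no step beyond the scatter. No supporting data bear on why these three groups read alike.

Still open is whether any group on this carbonyl carbon can move the number beyond the scatter, since only aromatic rings are shown there, and a cyclohexyl group, a longer alkyl chain or a phenyl ring carrying an amine or a carboxylic acid would each put that to the test. Also open, from the compounds shown here alone, is how much the ester linkage and the chlorine on the shared core contribute, for instance with an amide in place of the ester or hydrogen in place of the chlorine.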